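The source may report more compounds than this note shows. Statements on the series, on what has been measured and on what is new or still open speak of the compounds shown alone.

Measured so far in a physicochemical assay for solubility; on this read-out lower numbers stand for lower solubility and higher numbers for higher solubility:
- compound 1 `CNC(=O)c1cc(C(=O)NC2CC2)cn(Cc2ccc(F)cc2)c1=O` gives >= 162 ug/mL as a limit
- compound 2 `CNC(=O)c1cc(C(=O)NC2CC2)cn(Cc2cccc([C@@H](C)O)c2)c1=O` gives >= 131 ug/mL as a limit
- compound 3 `CNC(=O)c1cc(C(=O)NC2CC2)cn(Cc2cccc3c2CCN3)c1=O` gives >= 184 ug/mL as a limit

Compound 3 stands at >= 184 ug/mL in this series, and that is a limit, not a number. The other two entries are limits as well, so no ranking of the three can be drawn.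

Compound 4 `CNC(=O)c1cc(C(=O)NC2CC2)cn(Cc2cccc3cc[nH]c23)c1=O` carries one change from compound 3: 1H-indol-7-yl in place of 2,3-dihydro-1H-indol-4-yl on a saturated chain carbon bound to an aromatic nitrogen and the shared core stays as it is.

Two measured steps were taken at the same place, on a saturated chain carbon bound to an aromatic nitrogen. They are a step that the two limits leave unreadable from compound 1 to compound 3 and a step that the two limits leave unreadable from compound 2 to compound 3 and neither offers a size to carry over. With those steps unreadable, the expectation has no measured shift to build on, so no shift is assumed. What is expected in this assay is an at least 1.1-fold lower number from compound 3 to compound 4 (0.06 log units; that floor lies within the scatter) with nothing beyond the scatter and no firm direction. A further limit is also a likely outcome for compound 4.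

For compound 4 the estimated value is 160 ug/mL with an expected range from 70 ug/mL to 230 ug/mL in this assay.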

Compound 4, solubility: >= 144 ug/mL
Compound 4 gave a limit, no number; the forecaster's own chance of this, stated with the estimate: 65%; the middle value lies beyond the limit too.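

In this assay compound 4 gives >= 144 ug/mL, which is a limit and not a number. Compound 1, compound 2 and compound 3 are also limits, and the steps from each of them to compound 4 cannot be read. The compounds shown leave open how the four rank in this assay and whether 1H-indol-7-yl in place of 2,3-dihydro-1H-indol-4-yl shifts the read-out at all.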